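Swapping the furan for a benzofuran on a nucleoside core

The source may hold more compounds than are shown below. What is called first, only, known or untested is meant among the compounds shown, and "the series" means these compounds.

Compound 1, `COc1ncnc2c1c(-c1ccoc1)cn2[C@@H]1O[C@H](CO)[C@@H](O)[C@H]1O`, is tested in a functional assay on HCT-116 cells (Homo sapiens), read by MTT assay, with a stated time of 72 h (on this read-out lower numbers stand for stronger inhibition and higher numbers for weaker inhibition), where compound 1 gives 110 nM. Among the two plain numbers shown, compound 1 stands highest; compound 2, `CSc1ncnc2c1c(-c1ccoc1)cn2[C@@H]1O[C@H](CO)[C@@H](O)[C@H]1O`, gives 40 nM, which is a 2.8-fold lower number from compound 1 to compound 2 (0.44 log units; beyond the scatter). Compound 3, `CNc1ncnc2c1c(-c1ccoc1)cn2[C@@H]1O[C@H](CO)[C@@H](O)[C@H]1O`, gives only a limit of the assay, > 20000 nM. Compound 4, `COc1ncnc2c1c(-c1cc3ccccc3o1)cn2[C@@H]1O[C@H](CO)[C@@H](O)[C@H]1O`, differs from compound 1 at a different place: 1-benzofuran-2-yl in place of furan-3-yl on an aromatic carbon. Every measured step shown changes the methoxy group instead, so none of them bears on this change, and the data offer no direction for it. For compound 4 the expected step is a 2.3-fold higher number from compound 1 to compound 4 (0.36 log units; beyond the scatter), a cautious guess of a modest weakening. For compound 4 the estimate is 250 nM, expected to fall between 50 nM and 1500 nM.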

Compound 4, half-maximal inhibitory concentration: 13800 nM
For compound 4 the middle estimate is 55-fold (1.74 log units) below the measured one; the measured number lies above the stated range.
By their numbers in this assay, from the lowest: compound 2; then compound 1; then compound 4. At a limit, above all of these: compound 3.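

Among the compounds shown here, the group on this aromatic carbon matters as much as the earlier steps suggested for the methoxy site: in this assay there is a 130-fold higher number from compound 1 to compound 4 (2.10 log units; beyond the scatter). The change puts a six-membered aromatic ring of carbon only onto the furan and also moves the point of attachment, and activity does not tolerate the two together. The read-out also has a limit at its top end, which is not a number: the limit of > 20000 nM in this assay, at which 1 of the 4 values shown sits.

From the compounds shown here alone, whether the loss follows the added ring or the changed attachment stays open. A furan-2-yl group on this carbon would separate the two.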